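The source may report more compounds than this note shows. Statements on the series, on what has been measured and on what is new or still open speak of the compounds shown alone.

The measured compounds in a functional assay on MCF7 cells (Homo sapiens) for antiproliferative activity; on this read-out lower numbers stand for stronger inhibition and higher numbers for weaker inhibition:

compound 1, `CC/C=C/Cn1c(Cc2cc(OC)c(OC)c(OC)c2)nc2c(N)ncnc21`: 46800 nM
compound 2, `CC/C=C\Cn1c(Cc2cc(OC)c(OC)c(OC)c2)nc2c(N)ncnc21`: 64600 nM
compound 3, `COc1cc(Cc2nc3c(N)ncnc3n2CCCC(C)C)cc(OC)c1OC`: 69200 nM

All three share the same core and differ only in the chain carried on the aromatic nitrogen. Compound 3 gives the largest number of the three on paper, but its steps from the other two, a 1.5-fold higher number from compound 1 to compound 3 (0.17 log units; within the scatter) and a 1.1-fold higher number from compound 2 to compound 3 (0.03 log units; within the scatter), are both within the scatter, so the three are not really told apart. Compound 1 and compound 2 differ only in how the double bond is drawn, and the step of a 1.4-fold higher number from compound 1 to compound 2 (0.14 log units; within the scatter) is within the scatter as well, which fits (the fact that compounds 1 and 2 differ only in the configuration as drawn).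

Compound 4, `C=CCCn1c(Cc2cc(OC)c(OC)c(OC)c2)nc2c(N)ncnc21`, changes the chain once more: vinyl in place of isobutyl on a saturated chain carbon, two bonds along the chain from an aromatic nitrogen. For the measured compounds named here, the steps that bear on this are the two chain swaps already measured, from compound 1 and from compound 2 to compound 3, and both were within the scatter. A change on the same chain is therefore expected to give a step of a 1.2-fold lower number from compound 3 to compound 4 (0.06 log units; within the scatter) of no size beyond the scatter. For compound 4 the expected value in this assay is 60000 nM, with a range from 25000 nM to 150000 nM.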

Compound 4, half-maximal inhibitory concentration: 40700 nM
Compound 4: middle estimate off by 1.5-fold (0.17 log units), on the high side; measured number inside the range.
By their numbers in this assay, from the lowest: compounds 4, 1, 2 and 3 (each within the scatter of the next).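

In this assay, putting vinyl in place of isobutyl, on a saturated chain carbon two bonds along the chain from an aromatic nitrogen, gives a 1.7-fold lower number from compound 3 to compound 4 (0.23 log units; within the scatter), so removing the branched end and adding a double bond there does not separate the two compounds. Read against the chains that already held a double bond, allyl in place of but-1-en-1-yl on a saturated chain carbon bound to an aromatic nitrogen gives a 1.6-fold lower number from compound 2 to compound 4 (0.20 log units; within the scatter) and a 1.1-fold lower number from compound 1 to compound 4 (0.06 log units; within the scatter), so a shorter unsaturated chain also cannot be told apart from either longer one, and these four chains show no measurable preference at this position. No available fact bears on why this change leaves the number within the scatter.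

On these data alone, all four chains are made only of carbon and hydrogen, so it remains open whether a chain ending in an amine, a hydroxyl or a carboxylic acid would give a step beyond the scatter. A much longer chain, or a ring such as cyclohexyl or phenyl at the end of the chain, is equally untested among these compounds.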